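Carboxy for methyl on compound 3

The compounds below may be only part of what the source reports. "The series", "measured", "known", "first", "only" and "open" are said of these compounds alone.

Measured in an ADME assay (liver, Mus musculus) for metabolic stability, using microsomes; a higher number here means that the compound lasts longer, a lower number that the compound disappears faster:
- compound 1 `CCCc1nc2ccccn2c1C(=O)NCc1ccc(-c2ccccc2)cc1`: 0.145 h
- compound 2 `CCc1nc2ccc(Cl)cn2c1C(=O)NCc1ccc(-c2ccc(C#N)cc2)cc1`: > 1 h (a limit, not a number)
- compound 3 `CCc1nc2cc(Cl)ccn2c1C(=O)NCc1ccc(-c2ccc(C)cc2)cc1`: 0.385 h

Compound 3 at 0.385 h holds the higher of the two actual numbers, and compound 1 at 0.145 h lies lower, a gap beyond the scatter. The next case is compound 4 `CCc1nc2cc(Cl)ccn2c1C(=O)NCc1ccc(-c2ccc(C(=O)O)cc2)cc1`, with carboxy in place of methyl on an aromatic carbon, para to a large group (carboxy in place of methyl on an aromatic carbon). Among the compounds with values here, no measured pair shows this change alone. Within the data shown here, the only pointer is compound 2, which has no methyl at that place and reaches the limit > 1 h, though it differs elsewhere too. A rise beyond the scatter is therefore expected, as the estimated step of a 2.6-fold higher number from compound 3 to compound 4 (0.41 log units; beyond the scatter). Compound 4 is estimated at 1 h, with an expected range of 0.4 h to 3 h.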

Compound 4, half-life: > 2 h
Compound 4: only a limit was reported (the forecaster's own chance of this, stated with the estimate: 55%); middle value at least 2.0-fold (0.30 log units) away from the limit.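

In this assay, within the data shown here, going from 4-methylphenyl to 4-carboxyphenyl gives the only step here between compounds that differ in one place: an at least 5.1-fold higher number from compound 3 to compound 4 (0.71 log units; beyond the scatter). At this position, para to a large group, carboxy in place of methyl therefore lengthens the half-life on the shared core. Compound 4 carries a limit, not a number, and the full size of the step stays unknown: the limit of > 2 h in this assay, at which 1 of the 4 values shown sits.

Going by these compounds, whether a hydroxymethyl group or a primary amide at this position would give a comparable step remains open. So does whether the change holds with the propyl chain of compound 1.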